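Thiazolyl pyrazolines against lung carcinoma cells: working notes

This account rests on a few compounds, and the source may have more. Where it says the series, first, only, none or still open, it means among the compounds named here.

Measured so far:
compound 1 `Cc1ccc(C2=NN(c3nc(-c4ccccc4)cs3)C(c3ccc(F)cc3)C2)s1`, > 500 ug/mL
compound 2 `Fc1ccc(C2CC(c3ccc(Cl)s3)=NN2c2nc(-c3ccc(Br)cc3)cs2)cc1`, 62.5 ug/mL

In a functional assay on A549 cells (Homo sapiens) for antiproliferative activity, read by XTT assay, with a stated time of 24 h (a higher number here means a weaker inhibitor, a lower number a stronger inhibitor), compound 1 gives > 500 ug/mL, which is a limit of the assay and not a number. Compound 1 therefore stands at the limit of > 500 ug/mL in this assay, at which 1 of the 2 values shown sits, and nothing finer can be said of where it sits. In this assay, among the measured compounds shown here, compound 2 gives 62.5 ug/mL, a measured number; compound 2 differs from compound 1 in more than one place, so the two values show only that one compound reached a number and the other did not.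

Compound 3 `Cc1ccc(C2=NN(c3nc(-c4ccc(C(F)(F)F)cc4)cs3)C(c3ccc(F)cc3)C2)s1` remains to be measured. It differs from compound 1 by trifluoromethyl in place of hydrogen on an aromatic carbon, para to a large group. For the measured compounds named here, no step of this kind is known, so the expectation rests on compound 1 alone. The step of an at least 2.0-fold lower number from compound 1 to compound 3 (0.30 log units; that floor lies within the scatter) is expected to run toward a stronger inhibitor, but only modestly, and a limit again is a real possibility. Compound 3 is expected in this assay at 250 ug/mL, within 60 ug/mL to 600 ug/mL.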

Compound 3, half-maximal inhibitory concentration: > 500 ug/mL
Compound 3 ended at the assay's limit; the forecaster's own chance of this, stated with the estimate: 50%; middle value at least 2.0-fold (0.30 log units) away from the limit.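

In this assay, among the compounds shown here, compound 1 and compound 3 both stand at a limit of the assay and not at a number, so no step between the two can be read: the limit of > 500 ug/mL in this assay, at which 2 of the 3 values shown sit.
What the compounds shown leave open is whether trifluoromethyl in place of hydrogen on an aromatic carbon shifts the value in any compound that reaches a measured number.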